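Swapping an Aryl Substituent in a Sulfonamide Series

The compounds below may be only part of what the source reports. "The series", "measured", "known", "first", "only" and "open" are said of these compounds alone.

Compound 1 `CC1CCN(C2CCN(S(=O)(=O)c3cccc(-c4ccccc4C(F)(F)F)c3)CC2)CC1`: 0.617 h
Compound 2 `CC1CCN(C2CCN(S(=O)(=O)c3cc(Br)cc4c3OCC4)CC2)CC1`: 0.0833 h
Compound 3 `CC1CCN(C2CCN(S(=O)(=O)c3ccc(Cl)c(Cl)c3)CC2)CC1`: 0.55 h

These three compounds share a core and were tested in an ADME assay on S9 fraction from liver (Mus musculus, strain ICR/CD-1) for metabolic stability, read by LC-MS, using NADPH, with a stated time of 5 min, tested at 2 uM; a higher number here means that the compound lasts longer, a lower number that the compound disappears faster. Compound 1 shows the highest number of the three, but compound 3 sits within the scatter of it, so the two cannot be told apart. Compound 2 lies well below compound 1, beyond the scatter.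

Compound 4 `CC1CCN(C2CCN(S(=O)(=O)c3cccc(-c4ccc5ccccc5c4)c3)CC2)CC1` has not yet been measured. It differs from compound 1 in one place: naphthalen-2-yl in place of 2-(trifluoromethyl)phenyl on an aromatic carbon. Among the measured compounds shown here, no step between measured compounds isolates this change, so the expectation rests on compound 1 alone. The half-life of compound 4 in this assay is expected to be somewhat lower, a step from a 2.1-fold lower number from compound 1 to compound 4 (0.31 log units; beyond the scatter), possibly beyond the scatter. The estimate for compound 4 is 0.3 h, within a range from 0.1 h to 0.8 h.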

Compound 4, half-life: 3.4 h
The estimate for compound 4 lay 11-fold (1.05 log units) below the measured number; measured number above the stated range.
By their numbers in this assay, from the lowest: compound 2; then compounds 3 and 1 (each within the scatter of the next); then compound 4.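

At this place on the aromatic ring, the substituent can shift the half-life strongly: naphthalen-2-yl in place of 2-(trifluoromethyl)phenyl gives a 5.5-fold higher number from compound 1 to compound 4 (0.74 log units; beyond the scatter). The two groups have the same count of heavy atoms, so that count alone does not set the half-life here. Nothing measured here says what lies behind this step.

From the compounds shown here alone, it stays open whether the second aromatic ring or the absence of trifluoromethyl carries the step. Also open, going by these compounds, is what a plain phenyl group or a pyridyl ring would give at this place.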